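Swapping the Formyl Group for a Trifluoromethyl Group

The source may report more compounds than this note shows. Statements on the series, on what has been measured and on what is new or still open speak of the compounds shown alone.

Of the compounds shown here, three sharing one core have been measured in a functional assay on LOX IMVI cells (Homo sapiens) for inhibition, read by sulforhodamine B assay, with a stated time of 48 h, tested at 10 uM; on this read-out higher numbers stand for more inhibition at the one concentration tested (going by the name of the read-out) and lower numbers for less inhibition. Compound 1 `O=Cc1ccc(-c2cn3ccnc3c(-c3ccc4ncn(C5CCCCC5)c4c3)n2)cc1` gives 46.9%, the highest of the three. Compound 2 `COc1ccccc1-c1cn2ccnc2c(-c2ccc3ncn(C4CCCCC4)c3c2)n1` gives 5.13% and compound 3 `Fc1ccccc1-c1cn2ccnc2c(-c2ccc3ncn(C4CCCCC4)c3c2)n1` gives 5.77%. The unmeasured compound 4 `FC(F)(F)c1cccc(-c2cn3ccnc3c(-c3ccc4ncn(C5CCCCC5)c4c3)n2)c1` differs from compound 1 in one place: 3-(trifluoromethyl)phenyl in place of 4-formylphenyl on an aromatic carbon. Within the data shown here, two measured steps bear on this, since both also remove the 4-formylphenyl group: a number 41.8 percentage points lower from compound 1 to compound 2 (beyond the scatter) and a number 41.1 percentage points lower from compound 1 to compound 3 (beyond the scatter). Both are large drops, and the new group, like those two, carries no formyl. A drop of similar size is therefore expected, a number 36.9 percentage points lower from compound 1 to compound 4 (beyond the scatter). Compound 4 is estimated at 10%, with a range from 0% to 30%.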

Compound 4, a percentage reported as inhibition, at one concentration (the size of the read-out at that concentration, not a potency): 3.45%
Compound 4: middle estimate off by 6.6 percentage points, on the high side, within the range that was stated.
By their numbers in this assay, from the lowest: compounds 4, 2 and 3 (each within the scatter of the next); then compound 1.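

The third replacement of 4-formylphenyl on this aromatic carbon also loses most of the inhibition in this assay, with a number 43.5 percentage points lower from compound 1 to compound 4 (beyond the scatter). The new group falls level with the other two, with a number 2.3 percentage points lower from compound 3 to compound 4 (within the scatter) and a number 1.7 percentage points lower from compound 2 to compound 4 (within the scatter), so among these groups only 4-formylphenyl stands apart. No measurement here gives a reason for this.

Going by these compounds, whether the formyl group itself matters stays open, since every replacement also changes the rest of the group. A 4-carboxyphenyl or 4-(aminomethyl)phenyl group in the same place would help to separate these.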